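Fluorine on the benzyl ring of a dopamine receptor ligand

The source may hold more compounds than are shown below. What is called first, only, known or untested is meant among the compounds shown, and "the series" means these compounds.

Compound 1, `COc1ccccc1N1CCN(CCCNC(=O)NN(Cc2ccccc2)c2ccc(Cl)cc2)CC1`, gives 2.9 nM in an assay on CHO cells for displacement of a labelled ligand from D(4) dopamine receptor (Homo sapiens), read by radioligand binding; a higher number here means a weaker inhibitor, a lower number a stronger inhibitor.
Compound 2, `COc1ccccc1N1CCN(CCCNC(=O)NN(Cc2ccccc2)c2ccc(Br)cc2)CC1`, gives 3.4 nM in this assay.
Compound 3, `COc1ccc(N(Cc2ccccc2)NC(=O)NCCCN2CCN(c3ccccc3OC)CC2)cc1`, gives 1.7 nM in this assay.

Compound 3 has the lowest number of the three, but the steps of a 1.7-fold lower number from compound 1 to compound 3 (0.23 log units; within the scatter) and a 2.0-fold lower number from compound 2 to compound 3 (0.30 log units; within the scatter) both stay within the scatter, as does a 1.2-fold higher number from compound 1 to compound 2 (0.07 log units; within the scatter), so the three compounds cannot be ranked. Compound 4, `COc1ccc(N(Cc2cccc(F)c2)NC(=O)NCCCN2CCN(c3ccccc3OC)CC2)cc1`, differs from compound 3 by fluoro in place of hydrogen on an aromatic carbon. Among the compounds with values here, no measured step touches the benzyl ring; the steps seen elsewhere in the shared core were all within the scatter. The number for compound 4 in this assay is therefore expected to stay close to that of compound 3, with a 1.1-fold higher number from compound 3 to compound 4 (0.02 log units; within the scatter) as the estimated step. Compound 4 is estimated at 1.8 nM, between 0.7 nM and 4.5 nM.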

Compound 4, inhibition constant: 6.2 nM
For compound 4 the middle estimate is 3.4-fold (0.54 log units) below the measured one, outside the stated range (above it).
By their numbers in this assay, from the lowest: compounds 3, 1, 2 and 4 (each within the scatter of the next, the first and the last beyond it).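

Within the data shown here, the benzyl ring is not a silent place: in this assay, 3-fluorobenzyl in place of benzyl gives the first step here beyond the scatter, though only a modest one (a 3.6-fold higher number from compound 3 to compound 4 (0.56 log units; beyond the scatter)). A single fluoro, just one heavy atom, thus weakens binding more clearly than the chloro, bromo and methoxy swaps on the other aromatic ring did. Nothing measured here accounts for this shift.

As far as these compounds go, it remains open whether this step belongs to fluoro itself or to any group at this place. A methyl or a nitrile on the benzyl ring, or fluoro on another carbon of that ring, would help separate the two.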